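Cyclopropyl in Place of Butyl: Expected Cytotoxicity

The source may report more compounds than this note shows. Statements on the series, on what has been measured and on what is new or still open speak of the compounds shown alone.

Measured compounds:
Compound 1 `COc1nc2ccc(Br)cc2cc1C(c1ccccc1)n1cc(-c2ccccc2)nn1`: 8.25%
Compound 2 `CCCCc1cn(C(c2ccccc2)c2cc3cc(Br)ccc3nc2OC)nn1`: -3.47%

In an ADME assay on HEK293 cells (Homo sapiens) for cytotoxicity, read by sulforhodamine B assay, with a stated time of 48 h, tested at 10 uM (on this read-out lower numbers stand for less inhibition and higher numbers for more inhibition at the one concentration tested (going by the name of the read-out)), compound 1 gives 8.25%, while compound 2 gives -3.47%. Within the data shown here, the single step between them, a number 11.7 percentage points lower from compound 1 to compound 2 (beyond the scatter), came with butyl in place of phenyl on an aromatic carbon. Compound 2 thus stands lowest of the two numbers, with compound 1 the nearest and higher by a margin that lies beyond the scatter; both compounds sit in the region of little inhibition.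

Compound 3 `COc1nc2ccc(Br)cc2cc1C(c1ccccc1)n1cc(C2CC2)nn1` differs from compound 2 by cyclopropyl in place of butyl on an aromatic carbon. Among the measured compounds shown here, the only measured step, a number 11.7 percentage points lower from compound 1 to compound 2 (beyond the scatter), bears on this change in so far as it also swaps the group at the same aromatic carbon, but it exchanged a different pair of groups, so it gives only a loose guide. Since that step was modest and both measured numbers are small, compound 3 is expected to show a step of a number 4.5 percentage points higher from compound 2 to compound 3 (within the scatter) in this assay, which means no change beyond the scatter. Compound 3 is therefore estimated at 1%, within a range from -10% to 12%.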

Compound 3, a percentage reported as inhibition, at one concentration (the size of the read-out at that concentration, not a potency): 8.22%
Beside the measured number, compound 3's estimate is 7.2 percentage points below it; low and high end bracket the measured number.
By their numbers in this assay, from the lowest: compound 2; then compounds 3 and 1 (each within the scatter of the next).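

In this assay, cyclopropyl in place of butyl on this aromatic carbon gives a number 11.7 percentage points higher from compound 2 to compound 3 (beyond the scatter), so the lower number seen earlier does not hold for every non-aromatic group placed here. Cyclopropyl in place of phenyl gives a number 0 percentage points lower from compound 1 to compound 3 (within the scatter), which means that phenyl and cyclopropyl cannot be told apart in this test, and among the three groups only butyl, the one without a ring, stands apart from the other two. No measurement at hand explains why butyl behaves differently from the two groups with a ring.

The compounds shown leave open whether an open chain as such goes with the lower number, a question that a shorter chain such as ethyl, a longer one such as hexyl, or a ring of another size such as cyclohexyl could help to settle. Among these compounds, they also leave open how a group carrying an amine or a carboxylic acid would read at this same carbon, where all the numbers so far remain small.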